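The compounds below may be only part of what the source reports. "The series", "measured", "known", "first", "only" and "open" are said of these compounds alone.

Three analogues of one shared core are in hand. In a functional assay on cells (T-cell, Mus musculus, strain BALB/c) for inhibition, read by MTT assay, with stated times of 24 h and 72 h (a lower number here means a stronger inhibitor, a higher number a weaker inhibitor), compound 1 `COc1cc(-c2nnc(SCc3ccc(C)cc3)o2)ccc1O` gives 6210 nM, compound 2 `COc1cc(-c2nnc(SCc3cccc([N+](=O)[O-])c3)o2)ccc1O` gives 16000 nM, and compound 3 `COc1cc(-c2nnc(SCc3ccc(F)cc3)o2)ccc1O` gives 8190 nM. Compound 3 holds the second highest of the three numbers; its nearest neighbour is compound 1 and its furthest is compound 2, both within the scatter. Compound 4 `COc1cccc(CSc2nnc(-c3ccc(O)c(OC)c3)o2)c1` is still unmeasured and differs from compound 3 in one place: 3-methoxyphenyl in place of 4-fluorophenyl on a saturated chain carbon bound to a sulfur. Within the data shown here, the one measured step that bears on this exchange is a 1.3-fold higher number from compound 1 to compound 3 (0.12 log units; within the scatter); the numbers of compound 2 and compound 3 also sit within the scatter of each other. No step beyond the scatter is therefore expected in this assay. Compound 4 is estimated at 8500 nM, with a range from 4000 nM to 18000 nM, an expected step of a 1.0-fold higher number from compound 3 to compound 4 (0.02 log units; within the scatter).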

Compound 4, half-maximal inhibitory concentration: 7410 nM
For compound 4 the middle estimate is 1.1-fold (0.06 log units) above the measured one; low and high end bracket the measured number.
By their numbers in this assay, from the lowest: compounds 1, 4, 3 and 2 (each within the scatter of the next, the first and the last beyond it).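

On the saturated chain carbon bound to a sulfur, 3-methoxyphenyl in place of 4-fluorophenyl gives a 1.1-fold lower number from compound 3 to compound 4 (0.04 log units; within the scatter) in this assay and 3-methoxyphenyl in place of 4-methylphenyl gives a 1.2-fold higher number from compound 1 to compound 4 (0.08 log units; within the scatter) as steps that show the entering hydrogen-bond acceptor changes nothing beyond the scatter. Methoxy in place of nitro on an aromatic carbon gives a 2.2-fold lower number from compound 2 to compound 4 (0.33 log units; beyond the scatter) as a modest step that separates these two groups. No evidence on hand accounts for these steps.

Open, as far as these compounds go, is whether an amine or a carboxylic acid in place of methoxy on an aromatic carbon would move the number beyond the scatter, and in which direction. From the compounds shown here alone, a longer chain on the sulfur also remains open.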